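A Methyl Added to Compound 1

This account rests on a few compounds, and the source may have more. Where it says the series, first, only, none or still open, it means among the compounds named here.

Within the data shown here, in a functional assay on cardiac atrium (Cavia porcellus) (on this read-out lower numbers stand for an effect already at smaller amounts and higher numbers for an effect only at larger amounts of compound), compound 1 `COC(=O)C1=C(C)NC(C)=C(C(=O)OC)C1c1c(-c2cccs2)nc2sccn12` gives 1300 nM, the lower of the two numbers measured so far. Compound 2 `COC(=O)C1=C(C)NC(C)=C(C(=O)OC)C1c1c(-c2cccnc2)nc2sccn12` gives 28400 nM. Placing pyridin-3-yl where thiophen-2-yl stood produced a large step, a 22-fold higher number from compound 1 to compound 2 (1.34 log units; beyond the scatter), beyond the scatter.

Compound 3 `COC(=O)C1=C(C)NC(C)=C(C(=O)OC)C1c1c(-c2cccs2)nc2sc(C)cn12` keeps thiophen-2-yl and changes another part of compound 1: methyl replaces hydrogen on an aromatic carbon next to the ring sulfur (methyl in place of hydrogen on an aromatic carbon). Among the measured compounds shown here, the single measured step lies at a different place, and no measurement yet tests a methyl at this one. It offers no direction for the new change, though it does show that one substitution on this core can shift the number strongly. No step beyond the scatter is therefore expected in this assay, with wide uncertainty. The expected step is a 1.2-fold higher number from compound 1 to compound 3 (0.06 log units; within the scatter). Compound 3 is estimated at 1500 nM, within an expected range of 450 nM to 5000 nM.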

Compound 3, half-maximal effective concentration: 40500 nM
Compound 3: the middle estimate sits 27-fold (1.43 log units) below what was measured, outside the stated range (above it).
By their numbers in this assay, from the lowest: compound 1; then compounds 2 and 3 (each within the scatter of the next).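

In this assay, the aromatic carbon next to the ring sulfur proves to be a sensitive place on the core of compound 1: exchanging its hydrogen for a methyl, only 1 heavy atom, gives a 31-fold higher number from compound 1 to compound 3 (1.49 log units; beyond the scatter). This is a large step, as was the exchange at the other place, a 22-fold higher number from compound 1 to compound 2 (1.34 log units; beyond the scatter), so both changes shown on this core move the number upward strongly. No measurement shown here accounts for what the added methyl does at this position.

From the compounds shown here alone, whether a chlorine atom, an ethyl or a hydroxymethyl on this same carbon would move the number as far remains open. Also open, going by these compounds, is whether the methyl would produce a similar step with pyridin-3-yl in place of thiophen-2-yl.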